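This account rests on a few compounds, and the source may have more. Where it says the series, first, only, none or still open, it means among the compounds named here.

Compound 3 `Nc1ccccc1NC(=O)/C=C/c1ccc(Cn2cnc3c(Nc4cccc(OC(F)(F)F)c4)nc(Cl)nc32)cc1` is the anilino compound carrying a trifluoromethoxy group, and in a functional assay on NCI-H460 cells (Homo sapiens) for antiproliferative activity, read by CCK-8 assay, with a stated time of 72 h, tested at 8 uM (a higher number here means a stronger effect of the compound at the concentration tested, a lower number a weaker effect), compound 3 gives 66.7%, the highest of the three numbers measured. Compound 2 `Nc1ccccc1NC(=O)c1ccc(Cn2cnc3c(NCc4ccccc4)nc(Cl)nc32)cc1` lies close: in this assay compound 2 gives 61.2%, a gap to compound 3 that stays within the scatter. Compound 1 `Nc1ccccc1NC(=O)/C=C/c1ccc(Cn2cnc3c(Nc4cccc(Cl)c4)nc(Cl)nc32)cc1` sits well apart, since in this assay compound 1 gives 29.4%.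

The step to compound 4 `Nc1ccccc1NC(=O)/C=C/c1ccc(Cn2cnc3c(NCc4ccccc4)nc(Cl)nc32)cc1` is benzyl in place of 3-(trifluoromethoxy)phenyl on a nitrogen on an aromatic ring. For the measured compounds named here, no measured step covers this exact exchange. Going by the values given here, the only step on the same nitrogen is a number 37.3 percentage points higher from compound 1 to compound 3 (beyond the scatter), which concerns a different substituent and says little about a benzyl group. Compound 2, which already carries the benzylamino group though on a different linker, is the nearer guide, and its number in this assay is close to that of compound 3. Compound 4 is therefore expected to give a step of a number 6.7 percentage points lower from compound 3 to compound 4 (within the scatter) in this assay, probably within the scatter, and its value is estimated at 60%, with a range from 42% to 78%.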

Compound 4, a percentage reported as inhibition, at one concentration (the size of the read-out at that concentration, not a potency): 49.1%
Compound 4: middle estimate off by 10.9 percentage points, on the high side; the range from low to high includes it.
By their numbers in this assay, from the lowest: compound 1; then compound 4; then compounds 2 and 3 (each within the scatter of the next).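

In this assay the exchange for benzyl on this nitrogen runs in opposite directions depending on the group it replaces, with a number 17.6 percentage points lower from compound 3 to compound 4 (beyond the scatter) when 3-(trifluoromethoxy)phenyl leaves and a number 19.7 percentage points higher from compound 1 to compound 4 (beyond the scatter) when 3-chlorophenyl leaves. Among compounds 1, 3 and 4, then, neither the benzyl group nor an aromatic ring placed directly on the nitrogen goes with the higher number as such. For the compounds shown here, with the benzylamino group held constant, the linker can also be read for the first time, as 2-((2-aminophenyl)carbamoyl)ethenyl in place of (2-aminophenyl)carbamoyl gives a number 12.1 percentage points lower from compound 2 to compound 4 (beyond the scatter) and so the number of compound 2 does not carry over to the other linker.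

Still open, from the compounds shown here alone, is how a 3-(trifluoromethoxy)benzyl group or a longer phenethyl chain on this nitrogen would compare with these substituents. Nothing available explains any of these steps.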